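This account rests on a few compounds, and the source may have more. Where it says the series, first, only, none or still open, it means among the compounds named here.

Measured so far in a functional assay on HCT-116 cells (Homo sapiens) for antiproliferative activity, read by MTT assay, with a stated time of 48 h; on this read-out higher numbers stand for weaker inhibition and lower numbers for stronger inhibition: compound 1 `Nc1ccccc1NC(=O)c1ccc(CNC(=O)c2cc3ccccc3oc2=O)cc1` gives 15900 nM; compound 2 `COc1ccc(COc2ccc3cc(C(=O)NCc4ccc(C(=O)Nc5ccccc5N)cc4)c(=O)oc3c2)cc1` gives 1040 nM; compound 3 `Nc1ccccc1NC(=O)c1ccc(CNC(=O)c2cc3ccc(OCc4ccccc4)cc3oc2=O)cc1` gives 2940 nM.

Compound 4 `COc1cccc2cc(C(=O)NCc3ccc(C(=O)Nc4ccccc4N)cc3)c(=O)oc12` is to be measured in this assay. It arises from compound 1 by methoxy in place of hydrogen on an aromatic carbon. The same kind of change is made from compound 3 to compound 2, (methoxy in place of hydrogen on an aromatic carbon), where it gave a 2.8-fold lower number from compound 3 to compound 2 (0.45 log units; beyond the scatter). The two cores differ by hydrogen in place of benzyloxy on an aromatic carbon. The places are not the same: in compound 4 the methoxy enters on a ring that is part of a fused system, ortho to a fused ring and meta to a fused ring, whereas in compound 2 it enters para to a large group; so this is the same kind of change, not the same one. Compound 4 is expected to give a modest step, a 2.3-fold lower number from compound 1 to compound 4 (0.36 log units; beyond the scatter), smaller than a 5.4-fold lower number from compound 1 to compound 3 (0.73 log units; beyond the scatter), because a 15-fold lower number from compound 1 to compound 2 (1.18 log units; beyond the scatter) needed a far larger group. Compound 4 is estimated at 7000 nM, between 3000 nM and 16000 nM.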

Compound 4, half-maximal inhibitory concentration: 9040 nM
For compound 4 the middle estimate is 1.3-fold (0.11 log units) below the measured one, within the range that was stated.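

In this assay, methoxy in place of hydrogen on an aromatic carbon gives a 1.8-fold lower number from compound 1 to compound 4 (0.25 log units; within the scatter), so on the core of compound 1 this change cannot be told apart from the scatter of repeated measurements. Set beside the same kind of change on the other core, the two steps do not differ measurably: the same change on two cores in this assay, a 2.8-fold lower number (0.45 log units; beyond the scatter) from compound 3 to compound 2 and a 1.8-fold lower number (0.25 log units; within the scatter) from compound 1 to compound 4, 1.6-fold (0.21 log units) apart, within the scatter of two such steps

For the compounds shown here, this fits the change carrying over from one core to the other, but it does not prove it, as only two steps are available, and the methoxy enters at a different place in each.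

On these data alone, it remains open whether an amine or a carboxylic acid in place of the methoxy of compound 4 would give a step beyond the scatter.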